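The source may report more compounds than this note shows. Statements on the series, on what has been measured and on what is new or still open speak of the compounds shown alone.

Measured compounds:
- Compound 1, `COc1ccc(C2CC(c3ccccc3)=NN2C2=NC(=O)/C(=C3\C(=O)Nc4ccc(Br)cc43)S2)cc1`: in a functional assay on cells (Cancer cell lines, Homo sapiens) for cytotoxicity, read by sulforhodamine B assay, with a stated time of 48 h (a lower number here means a stronger inhibitor of growth, a higher number a weaker inhibitor of growth), compound 1 gives 180 nM
- Compound 2, `COc1ccc(C2CC(c3ccc4ccccc4c3)=NN2C2=NC(=O)/C(=C3\C(=O)Nc4ccccc43)S2)cc1`: in this assay compound 2 gives 670 nM

Within the data shown here, compound 2 stands at the higher of the two numbers in this assay, with compound 1 showing the lower number by a margin beyond the scatter; the two compounds differ in more than one place, so no single step connects them.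

Compound 3, `COc1ccc(C2CC(c3ccc4ccccc4c3)=NN2C2=NC(=O)/C(=C3\C(=O)Nc4ccc(Br)cc43)S2)cc1`, has not yet been measured. It differs from compound 2 in one place: bromo in place of hydrogen on an aromatic carbon. Compound 1 carries the same bromo group on its shared core and gives 180 nM, the lower of the two numbers, while compound 2 without it gives 670 nM. On that basis the expected step of a 1.9-fold lower number from compound 2 to compound 3 (0.28 log units; within the scatter) in this assay is downward and modest, as compound 1 and compound 2 also differ elsewhere. Compound 3 is estimated at 350 nM, within the range 120 nM to 1000 nM.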

Compound 3, concentration for 50% growth inhibition: 46 nM
Compound 3: the middle estimate sits 7.6-fold (0.88 log units) above what was measured; the measured number lies below the stated range.
By their numbers in this assay, from the lowest: compound 3; then compound 1; then compound 2.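

In this assay, among these compounds, bromo in place of hydrogen on an aromatic carbon gives a 15-fold lower number from compound 2 to compound 3 (1.16 log units; beyond the scatter) and so provides the first direct reading of this change at this position, a large step beyond the scatter. With the bromo group kept in both compounds, naphthalen-2-yl in place of phenyl on a carbon with a double bond to nitrogen gives a 3.9-fold lower number from compound 1 to compound 3 (0.59 log units; beyond the scatter) and shows that this second site also affects the number, by a modest step that is still beyond the scatter. No supporting data are available to explain either step.

The compounds shown leave open whether bromo would give a step of similar size with phenyl in place of naphthalen-2-yl. They also leave open how chloro or an amine on the same aromatic carbon would compare with bromo.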